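Hydroxy for Fluoro on a Shared Core: Expected Effect

The source may hold more compounds than are shown below. What is called first, only, known or untested is meant among the compounds shown, and "the series" means these compounds.

Measured so far:
compound 1, `C#CCSc1nc(Nc2ccc(F)cc2)c2ccncc2n1`: 17300 nM
compound 2, `C#CCSc1nc(Nc2cccc(OC)c2)c2ccncc2n1`: 17100 nM
compound 3, `C#CCSc1nc(Nc2cc(OC)c(OC)c(OC)c2)c2ccncc2n1`: 30700 nM

Of the compounds shown here, three have been tested in a functional assay on PC-3 cells (Homo sapiens) for inhibition, read by MTT assay, with a stated time of 72 h; on this read-out higher numbers stand for weaker inhibition and lower numbers for stronger inhibition. Among them compound 1 gives the second highest number of the three. Its nearest neighbour is compound 2, whose value lies within the usual scatter of that of compound 1, and even the furthest, compound 3, is within the scatter. All three therefore sit close together, and no ranking among them can be read from these numbers.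

Compound 4, `C#CCSc1nc(Nc2ccc(O)cc2)c2ccncc2n1`, has not been measured yet. It is built on the same core as compound 1 and differs from it in one place: hydroxy in place of fluoro on an aromatic carbon. Going by the values given here, no measured pair among the three compounds shows this change, so there is no earlier step to lean on; the only guide is that the three values are all within scatter of each other and that the change is small in what it counts.

On that basis the step from compound 1 to compound 4 in this assay is expected to be none beyond the scatter, a 1.0-fold lower number from compound 1 to compound 4 (0.01 log units; within the scatter). For compound 4 the estimate is 17000 nM, with a range from 6000 nM to 50000 nM.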

Compound 4, half-maximal inhibitory concentration: > 80000 nM
Compound 4: no number, only a limit; the forecaster's own chance of this, stated with the estimate: 5%; at least 4.7-fold (0.67 log units) between middle value and limit.
By their numbers in this assay, from the lowest: compounds 2, 1 and 3 (each within the scatter of the next). At a limit, above all of these: compound 4.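

In this assay, replacing fluoro with hydroxy on an aromatic carbon para to a large group gives an at least 4.6-fold higher number from compound 1 to compound 4 (0.66 log units; beyond the scatter), so inhibition weakens and this single-atom swap is not neutral. Compound 4 gives > 80000 nM, which is a limit and not a number. Going by these compounds alone, no earlier pair differed in only one place, so this 4-fluorophenyl to 4-hydroxyphenyl change is the first direct evidence that the group at this position can shift the read-out beyond the scatter.

The full size of the step stays open because compound 4 sits at a limit: the limit of > 80000 nM in this assay, at which 1 of the 4 values shown sits.

The compounds shown also cannot tell whether the hydrogen-bond donor and acceptor counted for hydroxy, which fluoro lacks, have anything to do with the shift, or whether the same swap would act alike elsewhere on the ring; an amine or a chloro group at this same place would offer further single-change comparisons with compound 1.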